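From isobutoxy to ethoxy on a shared core

The source may hold more compounds than are shown below. What is called first, only, known or untested is meant among the compounds shown, and "the series" means these compounds.

Within the data shown here, in a functional assay on 1A9 cells (Homo sapiens) for antiproliferative activity, read by sulforhodamine B assay, with a stated time of 3 days (a lower number here means that less compound is needed, a higher number that more compound is needed for the effect), compound 1 (`CCCC1=C(OC)C(CCC)(CCC)C(=O)/C(=C(O)\C=C\c2ccccc2)C1=O`) gives 3.7 uM and compound 2 (`CCCC1=C(OCC(C)C)C(CCC)(CCC)C(=O)/C(=C(O)\C=C\c2ccccc2)C1=O`) gives 6.9 uM so compound 2 sits within the scatter of the only other number. For compound 3 (`COC1=C(CC=C(C)C)C(=O)/C(=C(O)/C=C/c2ccccc2)C(=O)C1(CC=C(C)C)CC=C(C)C`) the result stands as "not determined" (no result reported) and offers no comparison. The change to compound 4 (`CCCC1=C(OCC)C(CCC)(CCC)C(=O)/C(=C(O)\C=C\c2ccccc2)C1=O`) is methyl in place of isopropyl on a saturated chain carbon bound to an oxygen on an unsaturated carbon and turns isobutoxy into ethoxy. Among the measured compounds shown here, the only measured step at this place is a 1.9-fold higher number from compound 1 to compound 2 (0.27 log units; within the scatter) and it put isopropyl in place of hydrogen. No step beyond the scatter is therefore expected in this assay for this change. The estimate amounts to a 1.4-fold lower number from compound 2 to compound 4 (0.16 log units; within the scatter) as the expected step. Compound 4 is expected at 4.8 uM with an estimated range from 2.4 uM to 9 uM once measured.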

Compound 4, concentration for half-maximal effect: 4.3 uM
For compound 4 the middle estimate is 1.1-fold (0.05 log units) above the measured one, within the range that was stated.
By their numbers in this assay, from the lowest: compounds 1, 4 and 2 (each within the scatter of the next).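

Shortening the chain on the oxygen gives a 1.6-fold lower number from compound 2 to compound 4 (0.21 log units; within the scatter) in this assay, and ethoxy set against methoxy gives a 1.2-fold higher number from compound 1 to compound 4 (0.07 log units; within the scatter) on the same scale. With ethoxy added, methoxy, ethoxy and isobutoxy on the shared core can no longer be told apart in this assay, so this change on a saturated chain carbon bound to an oxygen on an unsaturated carbon shows no readable effect. No measurement shown offers any explanation for this flat result.

Going by these compounds, it remains open whether a much longer chain on this oxygen, or an amine or a carboxylic acid at the end of that chain, would move the number beyond the scatter.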